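The compounds below may be only part of what the source reports. "The series", "measured", "known", "first", "only" and "open" are said of these compounds alone.

Measured so far:
- compound 1 `Cc1ccc(C)c(-c2nc(CN3CCC(C(=O)NCCCN4C[C@H](C)C[C@H](C)C4)CC3)c(C)o2)c1`: 0.5 h
- compound 2 `Cc1oc(-c2ccc(Cl)c(Cl)c2)nc1CN1CCC(C(=O)NCCCN2C[C@H](C)C[C@H](C)C2)CC1`: > 0.5 h (a limit of the assay, not a number)
- compound 3 `COc1cccc(OC)c1-c1nc(CN2CCC(C(=O)NCCCN3C[C@H](C)C[C@H](C)C3)CC2)c(C)o1`: 0.2 h

All three were tested in an ADME assay on microsomes from liver (Rattus norvegicus) for metabolic stability, read by LC-MS, using NADPH, at 37 degrees C; on this read-out higher numbers stand for a longer-lived compound and lower numbers for a shorter-lived compound. Only two of them give real numbers, and compound 3 holds the lower of these at 0.2 h. Its nearest neighbour is compound 1 at 0.5 h.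

The next structure is compound 4 `Cc1cc(C)cc(-c2nc(CN3CCC(C(=O)NCCCN4C[C@H](C)C[C@H](C)C4)CC3)c(C)o2)c1`, which has 3,5-dimethylphenyl in place of the 2,6-dimethoxyphenyl of compound 3 on an aromatic carbon (3,5-dimethylphenyl in place of 2,6-dimethoxyphenyl on an aromatic carbon).

For the measured compounds named here, two measured steps bear on this swap, and both involve putting 2,6-dimethoxyphenyl in. One is a 2.5-fold lower number from compound 1 to compound 3 (0.40 log units; beyond the scatter), and the other is an at least 2.5-fold lower number from compound 2 to compound 3 (0.39 log units; beyond the scatter). Both go down by a modest amount, beyond the scatter, although the second is tied to a limit. Compound 1 is the closer guide, since its 2,5-dimethylphenyl also carries two methyl groups. Taking 2,6-dimethoxyphenyl out again should therefore give a modest rise in this assay, roughly back to the level of compound 1 .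

The expected size of the change is a 2.5-fold higher number from compound 3 to compound 4 (0.40 log units; beyond the scatter). For compound 4 the estimated half-life is 0.5 h. The expected range for compound 4 runs from 0.25 h to 0.9 h. The assay may also report only a limit for this compound.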

Compound 4, half-life: < 0.5 h
Compound 4: a limit, no number (the forecaster's own chance of this, stated with the estimate: 35%); the middle value sits exactly at the limit.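

In this assay compound 4 gives < 0.5 h, which is a limit of the assay and not a number. As far as these compounds go, on the aromatic carbon that lies next to the ring nitrogen and next to the ring oxygen, the new group gives a number no higher from compound 1 to compound 4 (the limit leaves the size open) and a number no higher from compound 2 to compound 4 (the limit leaves the size open), so 3,5-dimethylphenyl brings no gain in half-life over either 2,5-dimethylphenyl or 3,4-dichlorophenyl, although the size of both steps stays open. The step between compound 3 and compound 4 cannot be read, because the result for compound 4 is only a limit: the limit of < 0.5 h in this assay, at which 1 of the 4 values shown sits.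

The compounds shown leave open how short-lived compound 4 really is, and so whether 3,5-dimethylphenyl or 2,6-dimethoxyphenyl gives the longer half-life at this position. They also leave open what a phenyl ring carrying an amine or a carboxylic acid, rather than the methyl, methoxy and chloro groups seen so far, would do to the half-life on this same aromatic carbon.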